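Bromo to Trifluoromethyl Repeated on a Second Core

The source may hold more compounds than are shown below. What is called first, only, known or untested is meant among the compounds shown, and "the series" means these compounds.

Measured in a functional assay on NCI-H1975 cells (Homo sapiens) for inhibition, read by sulforhodamine B assay, tested at 10 uM; a higher number here means more inhibition at the concentration tested (going by the name of the read-out), a lower number less inhibition:
Compound 1, `CN1CCN(c2ccc(C3=NN(S(=O)(=O)c4ccc(Br)cc4)C(c4ccc(N(C)C)cc4)C3)cc2)CC1`: 70.8%
Compound 2, `CN1CCN(c2ccc(C3=NN(S(=O)(=O)c4ccc(C(F)(F)F)cc4)C(c4ccc(N(C)C)cc4)C3)cc2)CC1`: 18.9%
Compound 3, `CN(C)c1ccc(C2CC(c3ccc(-n4cncn4)cc3)=NN2S(=O)(=O)c2ccc(Br)cc2)cc1`: -0.6%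

Compound 1 and compound 2 differ only by trifluoromethyl in place of bromo on an aromatic carbon, and that change produced a number 51.9 percentage points lower from compound 1 to compound 2 (beyond the scatter). Compound 3 differs from compound 1 by 1H-1,2,4-triazol-1-yl in place of 4-methylpiperazin-1-yl on an aromatic carbon, giving a number 71.4 percentage points lower from compound 1 to compound 3 (beyond the scatter), and compound 3 stands lowest of the three. Compound 4, `CN(C)c1ccc(C2CC(c3ccc(-n4cncn4)cc3)=NN2S(=O)(=O)c2ccc(C(F)(F)F)cc2)cc1`, is not yet measured; it differs from compound 3 by trifluoromethyl in place of bromo on an aromatic carbon, the same change on the same kind of place, so the step is the same kind of change set onto a different core. Because compound 3 already gives -0.6%, little room remains for a drop as large as the earlier one, so the expected step is a number 1.4 percentage points lower from compound 3 to compound 4 (within the scatter). Compound 4 is estimated at -2%, expected between -12% and 8%.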

Compound 4, a percentage reported as inhibition, at one concentration (the size of the read-out at that concentration, not a potency): 5.5%
The estimate for compound 4 lay 7.5 percentage points below the measured number; the range from low to high includes it.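

On the core carrying 1H-1,2,4-triazol-1-yl, trifluoromethyl in place of bromo gives a number 6.1 percentage points higher from compound 3 to compound 4 (within the scatter), so the large loss seen on the core of compound 1 did not carry over in this assay: the same change on two cores in this assay, a number 51.9 percentage points lower (beyond the scatter) from compound 1 to compound 2 and a number 6.1 percentage points higher (within the scatter) from compound 3 to compound 4, 58 percentage points apart, beyond the scatter of two such steps. The other change, 1H-1,2,4-triazol-1-yl in place of 4-methylpiperazin-1-yl, also differs with the group present, giving a number 13.4 percentage points lower from compound 2 to compound 4 (beyond the scatter) when trifluoromethyl is in place: the same change on two cores in this assay, a number 71.4 percentage points lower (beyond the scatter) from compound 1 to compound 3 and a number 13.4 percentage points lower (beyond the scatter) from compound 2 to compound 4, 58 percentage points apart, beyond the scatter of two such steps. This does not show why the steps differ, and since the numbers in this assay for compound 3 and compound 4 are both low, this pair cannot tell what the change would do on a compound with a higher number.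

Still open, going by these compounds, is whether chloro or methoxy in place of bromo, or morpholine in place of 4-methylpiperazin-1-yl, would keep the inhibition of compound 1.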